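The source may hold more compounds than are shown below. What is called first, only, known or untested is meant among the compounds shown, and "the series" means these compounds.

Compound 1 `Cc1cc(O)c(C2=NN(c3ccc(S(N)(=O)=O)cc3)C(c3ccccc3Cl)C2)cc1Cl` gives 4600 nM in a functional assay on EKVX cells (Homo sapiens) for antiproliferative activity, with a stated time of 48 h; a higher number here means a weaker inhibitor of growth, a lower number a stronger inhibitor of growth. Going by the values given here, compound 2 `COc1ccc(C2CC(c3cc(Cl)c(C)cc3O)=NN2c2ccc(S(N)(=O)=O)cc2)cc1OC` gives 100000 nM in this assay and stands highest of the two numbers so far, its nearest neighbour being compound 1, and the step of a 22-fold higher number from compound 1 to compound 2 (1.34 log units; beyond the scatter) lies beyond the scatter. Compound 3 `COc1ccc(C2CC(c3cc(Cl)c(C)cc3O)=NN2c2ccc(S(N)(=O)=O)cc2)c(OC)c1OC` differs from compound 2 by methoxy in place of hydrogen on an aromatic carbon: the change sits on an aromatic carbon of a six-membered aromatic ring of carbon only, ortho to a large group, ortho to a methoxy group and meta to a methoxy group, so that a 3,4-dimethoxyphenyl becomes a 2,3,4-trimethoxyphenyl. Among the compounds with values here, only one measured step bears on it, a 22-fold higher number from compound 1 to compound 2 (1.34 log units; beyond the scatter), which was large and touched the same ring, though through a different exchange. A third methoxy on that ring is therefore not expected to reverse the rise, and the step of no change at the digits printed from compound 2 to compound 3 (within the scatter) is estimated to stay within the scatter. For compound 3 the estimate in this assay is 100000 nM, within 30000 nM to 300000 nM.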

Compound 3, concentration for total growth inhibition: 43700 nM
Beside the measured number, compound 3's estimate is 2.3-fold (0.36 log units) above it, and the stated range covers the measured number.
By their numbers in this assay, from the lowest: compound 1; then compound 3; then compound 2.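

In this assay, methoxy on the aromatic carbon ortho to a large group, ortho to a methoxy group and meta to a methoxy group brings a 2.3-fold lower number from compound 2 to compound 3 (0.36 log units; beyond the scatter), so substitution at this carbon does shift the number, and in the direction of stronger growth inhibition. The shift recovers only part of the earlier rise, and a 9.5-fold higher number from compound 1 to compound 3 (0.98 log units; beyond the scatter) remains, which leaves the 2-chlorophenyl compound with the lowest number of the three. Nothing available explains this change.

The compounds shown leave open whether a hydroxyl or an amine on this same carbon would lower the number as methoxy does, or lower it further. They also leave open whether methoxy added to the 2-chlorophenyl ring of compound 1 would lower its number too.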